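This account rests on a few compounds, and the source may have more. Where it says the series, first, only, none or still open, it means among the compounds named here.

For the measured compounds named here, compound 1 `Cc1nc(Cl)cc(-c2ccccc2)c1C(=O)NCc1cc(C(F)(F)F)cc(C(F)(F)F)c1` and compound 2 `Cc1nc(Cl)cc(-c2ccccc2)c1C(=O)N(C)Cc1cc(C(F)(F)F)cc(C(F)(F)F)c1` are the two measured members. In an assay on CHO cells for displacement of a labelled ligand from Substance-P receptor (Homo sapiens), with a stated time of 90 min (a lower number here means a stronger inhibitor, a higher number a weaker inhibitor), compound 1 gives 270 nM, the highest of the two numbers; compound 2 gives 91 nM. Going by the values given here, the only measured step, methyl in place of hydrogen on an amide-type nitrogen, gave a 3.0-fold lower number from compound 1 to compound 2 (0.47 log units; beyond the scatter).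

Compound 3 `Cc1nc(N2CCN(C)CC2)cc(-c2ccccc2)c1C(=O)NCc1cc(C(F)(F)F)cc(C(F)(F)F)c1` differs from compound 1 by 4-methylpiperazin-1-yl in place of chloro on an aromatic carbon. Among the compounds with values here, no measured step touches this part of the shared core: the one step recorded concerns the amide nitrogen, so it offers no direct guide to a change at the aromatic carbon. With nothing in the data to point either way, the expectation for this assay is a step from compound 1 to compound 3 of a 1.1-fold lower number from compound 1 to compound 3 (0.03 log units; within the scatter), that is, no change beyond the scatter, with a wide band of uncertainty. Compound 3 is therefore expected to give about 250 nM, with a range from 50 nM to 1200 nM.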

Compound 3, half-maximal inhibitory concentration: 53 nM
The estimate for compound 3 lay 4.7-fold (0.67 log units) above the measured number; low and high end bracket the measured number.
By their numbers in this assay, from the lowest: compounds 3 and 2 (each within the scatter of the next); then compound 1.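

In this assay, the aromatic carbon next to the ring nitrogen, a part of the shared core that the amide-nitrogen step did not touch, proves sensitive to substitution: 4-methylpiperazin-1-yl in place of chloro gives a 5.1-fold lower number from compound 1 to compound 3 (0.71 log units; beyond the scatter). The position therefore takes a considerably larger group, a six-membered non-aromatic ring with 2 hetero atoms, with no loss of binding and a lower number beyond the scatter. Nothing measured here accounts for the shift, and this single step cannot separate the contributions of the ring, its nitrogens and its methyl group.

Still open, from the compounds shown here alone, is whether both ring nitrogens are needed, a question that piperidin-1-yl, morpholin-4-yl or a plain dimethylamino group at this carbon would address. Also open, going by these compounds, is whether methyl on the amide nitrogen would add to this change within one compound.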